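A few compounds are considered here, and "the series" means these few. Any claim that something is new, unique, unknown or untested is made for them only; others in the source may bear on it.

Series notes, cytotoxicity. In an ADME assay on MT4 cells (Homo sapiens) for cytotoxicity, read by MTT assay, with a stated time of 96 h (a higher number here means that more compound is tolerated, a lower number that less compound is tolerated), compound 1 `O=[N+]([O-])c1cccc(/N=N/N2CCCC2)c1` gives 66000 nM, the highest of the three numbers in hand. Compound 2 `CN(C)CCCN(/N=N/c1c(F)cccc1F)c1ccccc1` gives 23000 nM in this assay, and compound 3 `Cc1ccc(/N=N/c2ccc(NCCCN(C)C)cc2)cc1` gives 17000 nM; both sit below compound 1 by gaps beyond the scatter, compound 2 closer to it and compound 3 furthest away. For the measured compounds named here, no pair of these three differs in a single place, so no measured step is available to anchor the next change.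

Compound 4 `Clc1cccc(/N=N/N2CCCC2)c1` is the next entry: chloro in place of nitro on an aromatic carbon. With nothing measured on this change, the step of a 1.3-fold lower number from compound 1 to compound 4 (0.12 log units; within the scatter) from compound 1 is expected to be small, with any drift toward a lower number not going beyond the scatter. Compound 4 is accordingly estimated at 50000 nM, within 20000 nM to 120000 nM.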

Compound 4, half-maximal cytotoxic concentration: > 100000 nM
Compound 4: a limit, no number (the forecaster's own chance of this, stated with the estimate: 15%); middle value at least 2.0-fold (0.30 log units) away from the limit.
By their numbers in this assay, from the lowest: compounds 3 and 2 (each within the scatter of the next); then compound 1. At a limit, above all of these: compound 4.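

Compound 4 gives > 100000 nM in this assay and this is a limit, not a number. Chloro in place of nitro on this aromatic carbon reads as an at least 1.5-fold higher number from compound 1 to compound 4 (0.18 log units; that floor lies within the scatter) and so shows no fall in the number, though that floor alone does not separate the two compounds. How far the step runs cannot be read, since the reading stops at the limit: the limit of > 100000 nM in this assay, at which 1 of the 4 values shown sits.

Still open, going by these compounds, is whether an amine or a carboxylic acid on this aromatic carbon would hold the number as high as chloro does.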